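Swapping the aryl group on compound 3

The source may report more compounds than this note shows. Statements on the series, on what has been measured and on what is new or still open speak of the compounds shown alone.

Measured in a functional assay on A549 cells (Homo sapiens) for antiproliferative activity, read by MTT assay, with a stated time of 72 h; a lower number here means a stronger inhibitor, a higher number a weaker inhibitor:
Compound 1 `COc1ncc(-c2ccc3c(c2)N(c2ccc(C)cc2)C(=O)CO3)cc1NS(=O)(=O)c1ccc(F)cc1`: 5870 nM
Compound 2 `COc1ncc(-c2ccc3c(c2)N(c2ccc(F)cc2)C(=O)CO3)cc1NS(=O)(=O)c1ccc(F)cc1`: 6500 nM
Compound 3 `COc1cccc(N2C(=O)COc3ccc(-c4cnc5ccccc5c4)cc32)c1`: > 40000 nM, a limit and not a number

On these data alone, compound 3 sits at the limit of > 40000 nM in this assay, at which 1 of the 3 values shown sits, so its true value in this assay is unknown. Compound 4 `O=C1COc2ccc(-c3cnc4ccccc4c3)cc2N1c1ccc(F)cc1` keeps the rest of compound 3 and changes one group: 4-fluorophenyl in place of 3-methoxyphenyl on an amide-type nitrogen in a ring. In words, this is 4-fluorophenyl in place of 3-methoxyphenyl on an amide-type nitrogen in a ring.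

Within the data shown here, one measured step bears on this, and only loosely. It changes a group on the same nitrogen, and a 1.1-fold higher number from compound 1 to compound 2 (0.04 log units; within the scatter), with fluoro in place of methyl. Among the measured compounds shown here, no measured step removes the 3-methoxyphenyl. Compound 2 carries the 4-fluorophenyl and gives 6500 nM, but compounds 1 and 2 also differ from compound 3 elsewhere, so that value does not transfer directly. Compound 4 shares that other part with compound 3 and is therefore expected to stay close to it. The estimated change is small, at a number no higher from compound 3 to compound 4 (the limit leaves the size open), and it may not exceed the scatter. For compound 4 the expected value is 40000 nM, with an estimated range from 15000 nM to 80000 nM.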

Compound 4, half-maximal inhibitory concentration: > 40000 nM
Compound 4 was reported as a limit; the forecaster's own chance of this, stated with the estimate: 70%; the middle value lies on the limit itself.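

In this assay compound 3 gives > 40000 nM as a limit and not a number. Compound 4 gives > 40000 nM as a limit too. Among these compounds, no step from compound 3 to compound 4 can be read, because both stop at the same limit: the limit of > 40000 nM in this assay, at which 2 of the 4 values shown sit.

The compounds shown leave open the true values of compound 3 and compound 4, and so whether 4-fluorophenyl in place of 3-methoxyphenyl changes anything on this core.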